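The source may report more compounds than this note shows. Statements on the series, on what has been measured and on what is new or still open speak of the compounds shown alone.

Measured so far in an assay for inhibition of Tryptophan 2,3-dioxygenase (Homo sapiens), with a stated time of 1 h, tested at 10 uM; on this read-out lower numbers stand for less inhibition and higher numbers for more inhibition at the one concentration tested (going by the name of the read-out):
compound 1 `FC(F)(F)c1cccc(CNc2cc(Br)cc3[nH]ncc23)c1`: 56%
compound 2 `Nc1cc(CNc2cc(Br)cc3[nH]ncc23)ccc1O`: "not active" (no number reported)
compound 3 `Brc1cc(NCc2cccs2)c2cn[nH]c2c1`: 53%

Compound 3 and compound 1 give numbers within the scatter of each other, so neither stands apart from the other; compound 2 carries no number. The next entry, compound 4 `Brc1cc(NCc2ccncc2)c2cn[nH]c2c1`, differs from compound 3 in one place: pyridin-4-yl in place of thiophen-2-yl on a saturated chain carbon bound to a nitrogen on an aromatic ring. Within the data shown here, no step between two measured compounds is known, so nothing among the measured compounds shows what this exchange does to the read-out. The expected step in this assay is therefore a small one, a number 8 percentage points lower from compound 3 to compound 4 (within the scatter), not beyond the scatter, and the guess is broad. Compound 4 is expected to give 45%, with a range from 20% to 65%.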

Compound 4, a percentage reported as inhibition, at one concentration (the size of the read-out at that concentration, not a potency): 55%
Compound 4: middle estimate off by 10 percentage points, on the low side; measured number inside the range.
By their numbers in this assay, from the lowest: compounds 3, 4 and 1 (each within the scatter of the next).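

In this assay, among these compounds, pyridin-4-yl in place of thiophen-2-yl on a saturated chain carbon bound to a nitrogen on an aromatic ring gives a number 2 percentage points higher from compound 3 to compound 4 (within the scatter) as the first single-place step. At this position, at the one concentration tested, a five-membered and a six-membered aromatic ring therefore read alike. No evidence at hand bears on why they do.

Still open, on these data alone, is whether a carboxylic acid or an amine in place of the aromatic ring at this position would move the read-out beyond the scatter. As far as these compounds go, a longer chain between the ring and the nitrogen is equally open.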